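A Second Methyl on the Amide Ring

The source may report more compounds than this note shows. Statements on the series, on what has been measured and on what is new or still open speak of the compounds shown alone.

Three related compounds have been tested in a functional assay on A549 cells (Homo sapiens) for antiproliferative activity, read by CCK-8 assay, with a stated time of 72 h; a higher number here means a weaker inhibitor, a lower number a stronger inhibitor. Compound 1 `Cc1ccc(C(=O)Nc2cccc(-c3oc4cc(-c5ccc(F)cc5)ccc4c(=O)c3O)c2)cc1` gives 6910 nM. Compound 2 `O=C(Nc1cccc(-c2oc3cc(-c4ccc(F)cc4)ccc3c(=O)c2O)c1)c1ccc(Cl)cc1`, with a chloro in place of the methyl, gives 10800 nM in this assay. Compound 3 `Cc1cccc(C(=O)Nc2cccc(-c3oc4cc(-c5ccc(F)cc5)ccc4c(=O)c3O)c2)c1`, which carries a 3-methylphenyl instead of the 4-methylphenyl, gives 16500 nM in this assay; it stands at the highest number of the three, separated from compound 2 by a gap within the scatter and from compound 1 by a modest gap beyond it.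

Compound 4 `Cc1cc(C)cc(C(=O)Nc2cccc(-c3oc4cc(-c5ccc(F)cc5)ccc4c(=O)c3O)c2)c1` has not yet been measured. It differs from compound 3 by methyl in place of hydrogen on an aromatic carbon, turning the (3-methylphenyl)carbonyl into a (3,5-dimethylphenyl)carbonyl. Among the compounds with values here, no measured step adds a second methyl to this ring, so the expectation rests on the changes that touched the same ring: a 2.4-fold higher number from compound 1 to compound 3 (0.38 log units; beyond the scatter), and a 1.6-fold higher number from compound 1 to compound 2 (0.19 log units; within the scatter). Moving or swapping a single small group there shifted the number only modestly, never far past the scatter. A further methyl is therefore expected to change little, and the step is expected to be a 1.2-fold lower number from compound 3 to compound 4 (0.07 log units; within the scatter). Compound 4 is estimated at 14000 nM, within a range from 6000 nM to 35000 nM.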

Compound 4, half-maximal inhibitory concentration: 3740 nM
The estimate for compound 4 lay 3.7-fold (0.57 log units) above the measured number; the measured number lies below the stated range.
By their numbers in this assay, from the lowest: compounds 4, 1, 2 and 3 (each within the scatter of the next, the first and the last beyond it).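

In this assay, the second methyl brings the largest step among these four compounds, a 4.4-fold lower number from compound 3 to compound 4 (0.64 log units; beyond the scatter), and it is the first step here that lowers the number beyond the scatter, showing that one added methyl on this ring can count for more than the earlier single changes suggested. The 3,5-dimethylphenyl also separates from the 4-chlorophenyl, a 2.9-fold lower number from compound 2 to compound 4 (0.46 log units; beyond the scatter), yet it cannot be told apart from the 4-methylphenyl, a 1.8-fold lower number from compound 1 to compound 4 (0.27 log units; within the scatter), so the second methyl recovers and slightly exceeds the ground lost with the 3-methylphenyl without opening a clear lead over the best earlier compound. Nothing available explains why this added methyl has so much larger an effect than the earlier changes on the same ring.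

The compounds shown leave open whether two methyl groups are needed as such, or whether a 3,5-dichlorophenyl, a 3,5-dimethoxyphenyl or a 3,5-diethylphenyl would give a similar number. They also leave open how a plain phenyl, with only hydrogen on this ring, would compare with the four compounds here.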